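A few compounds are considered here, and "the series" means these few. Any claim that something is new, unique, unknown or untested is made for them only; others in the source may bear on it.

Measured compounds:
compound 1 `Cc1ccc(S(=O)(=O)Nc2ccc3c(c2)C(=O)N(CCNc2ccccc2)C3=O)cc1` gives 99600 nM in an assay on isolated protein for inhibition of lysosomal alpha-glucosidase (Rattus norvegicus), read by colorimetric assay; a higher number here means a weaker inhibitor, a lower number a stronger inhibitor
compound 2 `Cc1ccc(S(=O)(=O)Nc2ccc3c(c2)C(=O)N(CCOc2cccc(O)c2)C3=O)cc1` gives 55600 nM in this assay
compound 3 `Nc1ccc2c(c1)C(=O)N(CCNc1ccccc1)C2=O` gives 144000 nM in this assay

Compound 3 carries the highest number of the three in this assay. Its step from compound 1 is small, a 1.4-fold higher number from compound 1 to compound 3 (0.16 log units; within the scatter), so the two cannot be ordered. Against compound 2 the gap is wider: compound 2 gives 55600 nM, compound 3 gives 144000 nM, and that gap lies beyond the scatter of this assay.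

Compound 4 `O=C1c2ccccc2C(=O)N1CCNc1ccccc1` differs from compound 3 in one place: hydrogen in place of amino on an aromatic carbon. Within the data shown here, no measured step changes this position of the shared core in the same way. Among the measured compounds shown here, the only step touching that aromatic nitrogen, a 1.4-fold higher number from compound 1 to compound 3 (0.16 log units; within the scatter), kept the number within the scatter. The other step, a 1.8-fold lower number from compound 1 to compound 2 (0.25 log units; within the scatter), concerns the chain end and also stayed within the scatter. Both known changes on the periphery of the core left this assay nearly unmoved, so the expected step for compound 4 is small, a 1.2-fold higher number from compound 3 to compound 4 (0.07 log units; within the scatter), with no clear direction beyond the scatter. Compound 4 is therefore estimated at 170000 nM in this assay, with a likely range from 60000 nM to 480000 nM; a limit rather than a number is possible at this weak level.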

Compound 4, half-maximal inhibitory concentration: 184000 nM
Estimate against measurement, compound 4: 1.1-fold (0.03 log units) below, and the stated range covers the measured number.
By their numbers in this assay, from the lowest: compounds 2, 1, 3 and 4 (each within the scatter of the next, the first and the last beyond it).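

Among these compounds, the step for hydrogen in place of amino on this aromatic carbon, a 1.3-fold higher number from compound 3 to compound 4 (0.11 log units; within the scatter), is the first direct reading at this position, and it leaves compound 3 and compound 4 unordered in this assay. Read with the step that removes (4-methylphenyl)sulfonyl from the nitrogen on this carbon, a 1.4-fold higher number from compound 1 to compound 3 (0.16 log units; within the scatter), the series now runs in two single changes from the substituted nitrogen to the amino group to plain hydrogen, and neither change leaves the scatter. Nothing measured on these compounds offers an explanation for this flat reading at the position.

Going by these compounds, only the anilino chain end has been read with hydrogen at this carbon, so it remains open whether the same holds with the 3-hydroxyphenoxy chain end of compound 2. Also open, on these data alone, is whether a carboxylic acid or a methoxy group on this aromatic carbon, or a longer chain carrying the anilino group, would give a step beyond the scatter.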